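The compounds below may be only part of what the source reports. "The series", "measured", "known", "first", "only" and "open" are said of these compounds alone.

In a functional assay on the whole organism for inhibition, with Rattus norvegicus as the target, read by paw edema (on this read-out higher numbers stand for an effect only at larger amounts of compound and lower numbers for an effect already at smaller amounts), the compounds measured so far are:

compound 1 `O=C(O)c1cc(-c2ncccn2)ccc1O`: 100 mg/kg
compound 2 `O=C(O)c1cc(-c2cocn2)ccc1O`: 110 mg/kg
compound 3 `O=C(O)c1cc(-n2cnnc2)ccc1O`: reaches only the limit of the assay, > 250 mg/kg

Compound 2 holds the highest of the two numbers shown in this assay, but compound 1, its nearest, lies within the usual scatter of it, so no order between the two can be read. Compound 3 stands at the limit of this assay, at which one of the three values shown sits (the limit of > 250 mg/kg in this assay, at which 1 of the 3 values shown sits).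

Compound 4 `O=C(O)c1cc(-c2ccno2)ccc1O` has not yet been measured. It differs from compound 2 in one place: 1,2-oxazol-5-yl in place of 1,3-oxazol-4-yl on an aromatic carbon. The two have the same atoms, joined differently; the group on the aromatic carbon changes from 1,3-oxazol-4-yl to 1,2-oxazol-5-yl.

For the measured compounds named here, one measured step bears on this: an at least 2.2-fold higher number from compound 2 to compound 3 (0.35 log units; beyond the scatter). There the five-membered ring with two hetero atoms gave way to 4H-1,2,4-triazol-4-yl, and the number moved to the limit. The change to compound 4 keeps the same atoms and only rearranges them, so a smaller movement is expected, a 1.2-fold higher number from compound 2 to compound 4 (0.07 log units; within the scatter), not beyond the scatter. Compound 4 is therefore estimated to give 130 mg/kg in this assay, with a range from 60 mg/kg to 250 mg/kg.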

Compound 4, dose for half-maximal effect: 110 mg/kg
The estimate for compound 4 lay 1.2-fold (0.07 log units) above the measured number, and the stated range covers the measured number.
By their numbers in this assay, from the lowest: compounds 1, 2 and 4 (each within the scatter of the next). At a limit, above all of these: compound 3.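

In this assay, for the compounds shown here, the exchange of 1,3-oxazol-4-yl for 1,2-oxazol-5-yl, on the aromatic carbon meta to a carboxy group and para to a hydroxy group, gives no change at the digits printed from compound 2 to compound 4 (within the scatter); this is the first step in which the ring keeps the same atoms and only their arrangement differs, and it shows that this rearrangement moves the number by nothing this read-out can separate. The exchange of 4H-1,2,4-triazol-4-yl for 1,2-oxazol-5-yl gives an at least 2.2-fold lower number from compound 3 to compound 4 (0.35 log units; beyond the scatter), so the gap to the triazole, until now seen only against the 1,3-oxazol-4-yl of compound 2, appears with a second oxazole as well. The size of both gaps stays open-ended, as compound 3 stands at a limit of the assay and not at a number: the limit of > 250 mg/kg in this assay, at which 1 of the 4 values shown sits.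

The compounds shown leave open whether a thiazole, a plain phenyl ring or an open-chain group such as an amide or an amine at this place would stay within the scatter of the oxazoles or move beyond it. They also leave open what an ester or an amide in place of the carboxylic acid of the shared core would do to the number.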